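The compounds below may be only part of what the source reports. "The series", "measured", "known", "first", "only" and "open" are said of these compounds alone.

Measured compounds:
compound 1 `Cc1ccc(-c2nn(-c3ccccc3)cc2C(=O)NOCc2ccccc2F)cc1`: 2110 nM
compound 2 `Cc1ccc(-c2nn(-c3ccccc3)cc2C(=O)NOCc2ccccc2Cl)cc1`: 2640 nM
compound 3 `O=C(NOCc1ccccc1F)c1cn(-c2ccccc2)nc1-c1ccc(F)cc1`: 12000 nM

All three share one core and were tested in a functional assay on MCF7 cells (Homo sapiens) for antiproliferative activity, read by MTT assay, with a stated time of 48 h, in the presence of a further agent that is not named here; a higher number here means a weaker inhibitor of growth, a lower number a stronger inhibitor of growth. Compound 1 and compound 2 differ by chloro in place of fluoro on an aromatic carbon; the step of a 1.3-fold higher number from compound 1 to compound 2 (0.10 log units; within the scatter) is small. Compound 1 and compound 3 differ in the core by fluoro in place of methyl on an aromatic carbon, and here the step of a 5.7-fold higher number from compound 1 to compound 3 (0.75 log units; beyond the scatter) is clearer. Between compound 2 and compound 3 no single step is counted; their values simply show compound 3 at the higher number. Compound 3 thus stands highest of the three in this assay, beyond the scatter from both others.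

Compound 4 `O=C(NOCc1ccccc1Cl)c1cn(-c2ccccc2)nc1-c1ccc(F)cc1` is not yet measured. It differs from compound 3 by chloro in place of fluoro on an aromatic carbon, which is the same change as from compound 1 to compound 2, made on the other core. Because the earlier step of a 1.3-fold higher number from compound 1 to compound 2 (0.10 log units; within the scatter) stayed within the scatter, a similarly small step is expected here, so compound 4 is estimated to give about 15000 nM in this assay, with an expected range from 7000 nM to 32000 nM. Among the compounds with values here, the expected step from compound 3 is a 1.3-fold higher number from compound 3 to compound 4 (0.10 log units; within the scatter), resting on the single earlier pair only.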

Compound 4, concentration for 50% growth inhibition: 11400 nM
Compound 4: middle estimate off by 1.3-fold (0.12 log units), on the high side, within the range that was stated.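

In this assay, chloro in place of fluoro on an aromatic carbon gives a 1.1-fold lower number from compound 3 to compound 4 (0.02 log units; within the scatter), which agrees with the same change on the core of compound 1: the same change on two cores in this assay, a 1.3-fold higher number (0.10 log units; within the scatter) from compound 1 to compound 2 and a 1.1-fold lower number (0.02 log units; within the scatter) from compound 3 to compound 4, 1.3-fold (0.12 log units) apart, within the scatter of two such steps

Fluoro in place of methyl on an aromatic carbon, now read with the 2-chlorobenzyl group in place, gives a 4.3-fold higher number from compound 2 to compound 4 (0.64 log units; beyond the scatter), which repeats the step seen with the 2-fluorobenzyl group: the same change on two cores in this assay, a 5.7-fold higher number (0.75 log units; beyond the scatter) from compound 1 to compound 3 and a 4.3-fold higher number (0.64 log units; beyond the scatter) from compound 2 to compound 4, 1.3-fold (0.12 log units) apart, within the scatter of two such steps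

Across these four compounds, each change therefore carries from one core to the other at a similar size, but each comparison rests on one pair of steps and shows neither the reason for this nor that it holds beyond these compounds.

Open, as far as these compounds go, is whether the same carry-over holds with a methoxy group or a nitrile in place of the chloro or fluoro of the 2-chlorobenzyl and 2-fluorobenzyl groups. Also open, from the compounds shown here alone, is whether it holds with an amine or a carboxylic acid in place of the methyl of compound 1.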